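Tetrazole for carboxylic acid on a quinoline-ether leukotriene series

The source may hold more compounds than are shown below. What is called first, only, known or untested is meant among the compounds shown, and "the series" means these compounds.

Compounds measured so far:
compound 1 `CC(CCC(=O)O)Cc1cccc(OCc2ccc3ccccc3n2)c1`: 140 nM
compound 2 `O=C(O)CCC(Cc1cccc(OCc2ccc3ccccc3n2)c1)c1ccccc1`: 52 nM
compound 3 `c1ccc2nc(COc3ccc(CC4CCCC4Cc4nnn[nH]4)cc3)ccc2c1`: 15 nM

Of the compounds shown here, three sharing a quinolinylmethoxy-phenyl core have been measured in an assay on membranes from lung (Cavia porcellus) for binding affinity to cysteinyl leukotriene receptor (Homo sapiens); on this read-out lower numbers stand for stronger inhibition and higher numbers for weaker inhibition. Compound 1 gives the highest number of the three in this assay; compound 2 lies nearest to it, and compound 3 lies furthest from it. Within the data shown here, the one change among the measured compounds that differs in a single place is a 2.7-fold lower number from compound 1 to compound 2 (0.43 log units; beyond the scatter), a modest gain.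

Compound 4 `CC(CCc1nnn[nH]1)Cc1cccc(OCc2ccc3ccccc3n2)c1` is not yet measured. It differs from compound 1 in that (1H-tetrazol-5-yl in place of carboxy on a saturated chain carbon, four bonds along the chain from an aromatic carbon). Among the measured compounds shown here, no measured pair tells directly what this exchange does on this core; compound 3 carries a tetrazole too, but on a different saturated ring and with a different substitution pattern of the shared core, so its value shows only that a tetrazole-bearing compound can reach a low number in this assay. The step from compound 1 to compound 2 shows that a change at the chain can move the number beyond the scatter, without saying how the acid-for-tetrazole exchange behaves.

On that basis compound 4 is expected to give 60 nM in this assay, within a range of 15 nM to 250 nM, which corresponds to an expected step of a 2.3-fold lower number from compound 1 to compound 4 (0.37 log units; beyond the scatter).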

Compound 4, inhibition constant: 34 nM
For compound 4 the middle estimate is 1.8-fold (0.25 log units) above the measured one; the measured number falls inside the stated range.
By their numbers in this assay, from the lowest: compound 3; then compounds 4 and 2 (each within the scatter of the next); then compound 1.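

In this assay the exchange of carboxy for 1H-tetrazol-5-yl can now be read directly on one core, and it gives a 4.1-fold lower number from compound 1 to compound 4 (0.61 log units; beyond the scatter) as a modest step. Compound 3 had shown only that a tetrazole-bearing compound can reach a low number, whereas this pair shows that carboxy is not required at this place, on a saturated chain carbon four bonds along the chain from an aromatic carbon, and that its replacement lowers the number in this read-out. Together with the phenyl-for-methyl change, which gives a 2.7-fold lower number from compound 1 to compound 2 (0.43 log units; beyond the scatter) as its step, this makes two single changes on the chain of compound 1 that each lower the number beyond the scatter, but no measurement shown explains why the tetrazole exchange has this effect.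

From the compounds shown here alone, what stays open is whether the same exchange holds on the phenyl-bearing chain of compound 2, and whether the phenyl and tetrazole changes would add up when combined. Also open, going by these compounds, is how a longer chain ending in 1H-tetrazol-5-yl, or an acylsulfonamide at the same place, would read in this assay on this core.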